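The source may hold more compounds than are shown below. What is called first, only, known or untested is meant among the compounds shown, and "the series" means these compounds.

Compound 1 `CCCCOc1ccc(C(=O)NNc2c(Br)cccc2Br)cc1`: > 100000 nM
Compound 2 `COc1cccc(C(=O)NNc2c(Br)cccc2Br)c1`: > 100000 nM

In a toxicity assay on MDCK cells (Canis lupus familiaris) for cytotoxicity, read by CCK-8 assay, with a stated time of 48 h (on this read-out higher numbers stand for lower toxicity in this test and lower numbers for higher toxicity in this test), compound 1 reads > 100000 nM, which is a limit and not a number. Compound 2 reads > 100000 nM, which is also a limit. Within the data shown here, compound 1 therefore stands at the limit of > 100000 nM in this assay, at which 2 of the 2 values shown sit, and no measured step is available. Compound 3 `COC(=O)c1ccc(C(=O)NNc2c(Br)cccc2Br)cc1` has methoxycarbonyl in place of butoxy on an aromatic carbon. No change beyond the usual scatter is expected in this assay, an expectation resting only on compound 1 and its limit of > 100000 nM. The estimated step is a number no higher from compound 1 to compound 3 (the limit leaves the size open). The expected value for compound 3 is 100000 nM, within an estimated range of 40000 nM to 200000 nM.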

Compound 3, half-maximal cytotoxic concentration: 87600 nM
Compound 3: middle estimate off by 1.1-fold (0.06 log units), on the high side; the measured number falls inside the stated range.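

In this assay, compound 3 gives the first actual number among these compounds, 87600 nM, so methoxycarbonyl in place of butoxy at this position, para to a large group, yields a value that can be read. As a step, this is an at least 1.1-fold lower number from compound 1 to compound 3 (0.05 log units; that floor lies within the scatter). Its true size stays open because compound 1 carries only a limit: the limit of > 100000 nM in this assay, at which 2 of the 3 values shown sit.

The compounds shown leave open whether an amine or a carboxylic acid on this aromatic carbon would give a clearly lower number. They also leave open what such groups would do elsewhere on the ring.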